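This account rests on a few compounds, and the source may have more. Where it says the series, first, only, none or still open, it means among the compounds named here.

Three compounds of one series, compound 1 `CCON/C(=N\C1=NC(=O)C(=O)N1C(C)C)Nc1ccc(Cl)c(Cl)c1`, compound 2 `CC(C)N1C(=O)C(=O)N=C1/N=C(\NOCc1ccccc1)Nc1ccc(Cl)c(Cl)c1` and compound 3 `CC(C)N/C(=N\C1=NC(=O)C(=O)N1C(C)C)Nc1ccc(Cl)c(Cl)c1`, were run in an in vitro ADME assay on microsomes from liver (Mus musculus) for metabolic stability, read by LC-MS; a higher number here means that the compound lasts longer, a lower number that the compound disappears faster. For compound 1 this assay returns only a limit, > 1 h. For compound 2 it likewise returns only a limit, > 1 h. Compound 3 too gives only a limit, > 1 h. Because all three sit at the limit of > 1 h in this assay, at which 3 of the 3 values shown sit, the steps between them cannot be read: a step that the two limits leave unreadable from compound 1 to compound 2, a step that the two limits leave unreadable from compound 1 to compound 3 and a step that the two limits leave unreadable from compound 2 to compound 3. Within the data shown here, compound 3 therefore stands where every measured value in this set stands, at the limit, and no compound can be set above or below another.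

Compound 4 `CC(C)N1C(=O)C(=O)N=C1/N=C(\NCC(C)(C)C)Nc1ccc(Cl)c(Cl)c1` is yet to be measured in this assay. It differs from compound 3 in one place: neopentyl in place of isopropyl on an amine nitrogen. Among the measured compounds shown here, none of the measured steps concerns this change, and none of them has a readable size, so they give no direction. Compound 4 is expected to sit near the limit, the expected step being a step that the limit leaves unreadable from compound 3 to compound 4. The half-life of compound 4 in this assay is thus estimated at 1.5 h, with a range from 0.5 h to 4 h.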

Compound 4, half-life: > 1 h
Compound 4 ended at the assay's limit; the forecaster's own chance of this, stated with the estimate: 65%; the middle value does not contradict the limit.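

Compound 4 joins compound 1, compound 2 and compound 3 at the limit in this assay and so none of the steps to compound 4 can be read: the limit of > 1 h in this assay, at which 4 of the 4 values shown sit.

The compounds shown leave open how long each actually lasts, and whether neopentyl, isopropyl, ethoxy or benzyloxy on the amine nitrogen makes any difference.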